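The compounds below may be only part of what the source reports. "The series", "measured", "known", "first", "only" and "open" are said of these compounds alone.

In a functional assay on MDA-MB-231 cells (Homo sapiens) for cytotoxicity, read by MTT assay, with a stated time of 48 h (on this read-out higher numbers stand for weaker inhibition and lower numbers for stronger inhibition), compound 2 `COc1ccc(CN(C(=O)Nc2ccc(C#N)cc2)n2cnnc2)cc1OC` reaches only the assay's limit, > 50000 nM, which is a limit and not a number. Compound 1 `COc1cc(CN(C(=O)Nc2ccc(C#N)cc2)n2cnnc2)cc(OC)c1OC` likewise stops at a limit, > 50000 nM. The step that the two limits leave unreadable from compound 1 to compound 2 is unreadable for that reason, and the limit of > 50000 nM in this assay, at which 2 of the 3 values shown sit, holds both. Compound 3 `Cc1ccc(NC(=O)N(Cc2ccccn2)n2cnnc2)cc1` does give a number in this assay, 39500 nM, still a weak one. Compound 4 `COc1ccc(CN(C(=O)Nc2ccc(F)c(Cl)c2)n2cnnc2)cc1OC` differs from compound 2 by 3-chloro-4-fluorophenyl in place of 4-cyanophenyl on an amide-type nitrogen. Among the compounds with values here, no measured step exchanges this group, so none bears directly on the change, and the expectation rests on compound 2 alone. Compound 4 is expected to show a step of a number no higher from compound 2 to compound 4 (the limit leaves the size open), nothing beyond the scatter. Compound 4 is thus estimated at 50000 nM, between 20000 nM and 120000 nM.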

Compound 4, half-maximal inhibitory concentration: 27900 nM
Beside the measured number, compound 4's estimate is 1.8-fold (0.25 log units) above it, and the stated range covers the measured number.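

In this assay, 3-chloro-4-fluorophenyl in place of 4-cyanophenyl on the amide-type nitrogen gives an at least 1.7-fold lower number from compound 2 to compound 4 (0.25 log units; that floor lies within the scatter). Within the data shown here, this is the first readable step here, and it shows that a change at this place can turn a limit into a real number. The true size of the step stays unknown because compound 2 has no number of its own: the limit of > 50000 nM in this assay, at which 2 of the 4 values shown sit.

Going by these compounds, whether an amine or a carboxylic acid on this phenyl ring would lower the number further stays open. So does whether 3-chloro-4-fluorophenyl would also give a number on the core of compound 1.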